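The compounds below may be only part of what the source reports. "The series", "measured", "known", "first", "only" and "open" are said of these compounds alone.

Compound 1 `O=C(COc1ccc2cc(/C=C3/SC(=O)NC3=O)ccc2c1)Nc1c(F)cc(F)cc1Br` is recorded in an assay on isolated protein for inhibition of histone deacetylase 8 (Homo sapiens), with a stated time of 1 h (on this read-out higher numbers stand for weaker inhibition and lower numbers for stronger inhibition), only as a limit, > 50000 nM, so its position on the scale is open; it stands at the limit of > 50000 nM in this assay, at which 1 of the 2 values shown sits. Compound 2 `O=C(COc1ccc2ccccc2c1/C=C1\SC(=O)NC1=O)Nc1ccc([N+](=O)[O-])cc1` gives 2300 nM in this assay. Compound 3 `O=C(COc1ccc2cc(/C=C3/SC(=O)NC3=O)ccc2c1)Nc1ccc([N+](=O)[O-])cc1` is not yet measured. The change from compound 1 to compound 3 is 4-nitrophenyl in place of 2-bromo-4,6-difluorophenyl on an amide-type nitrogen, and compound 2 carries the same 4-nitrophenyl on its amide-type nitrogen and returns a number. A step toward stronger inhibition, beyond the scatter, is expected: an at least 8.3-fold lower number from compound 1 to compound 3 (0.92 log units; beyond the scatter). Compound 3 is estimated at 6000 nM, between 1500 nM and 30000 nM.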

Compound 3, half-maximal inhibitory concentration: 4000 nM
For compound 3 the middle estimate is 1.5-fold (0.18 log units) above the measured one; low and high end bracket the measured number.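

On the core of compound 1, the group on the amide-type nitrogen decides whether this assay returns a number at all: 4-nitrophenyl in place of 2-bromo-4,6-difluorophenyl gives an at least 12-fold lower number from compound 1 to compound 3 (1.09 log units; beyond the scatter) in this assay. The size of this step has only a lower bound, as one end of it is a limit of the assay: the limit of > 50000 nM in this assay, at which 1 of the 3 values shown sits.

The compounds shown do not separate the loss of the bromine and fluorines from the gain of the nitro group. From the compounds shown here alone, how a plain phenyl, or an amine or a carboxylic acid in place of the nitro group, would read remains open.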